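Removing phosphates from a methylated uridine nucleotide

This account rests on a few compounds, and the source may have more. Where it says the series, first, only, none or still open, it means among the compounds named here.

Compound 1, `Cn1c(=O)ccn([C@@H]2O[C@H](COP(=O)(O)OP(=O)(O)OP(=O)(O)O)[C@@H](O)[C@H]2O)c1=O`, gives in an in vitro functional assay on 1321-N1 cells for agonist activity at P2Y purinoceptor 6 (Homo sapiens) (on this read-out lower numbers stand for an effect already at smaller amounts and higher numbers for an effect only at larger amounts of compound), a limit, > 1000 nM. Compound 2, `Cn1c(=O)ccn([C@@H]2O[C@H](COP(=O)(O)OP(=O)(O)O)[C@@H](O)[C@H]2O)c1=O`, gives in this assay a limit, > 1000 nM. Compound 3, `Cc1cc(=O)n([C@@H]2O[C@H](COP(=O)(O)OP(=O)(O)O)[C@@H](O)[C@H]2O)c(=O)[nH]1`, gives in this assay a limit, > 1000 nM.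

Compound 2 thus stands only at a limit, and the two other values shown are limits as well. Compound 4, `Cn1c(=O)ccn([C@@H]2O[C@H](COP(=O)(O)O)[C@@H](O)[C@H]2O)c1=O`, differs from compound 2 in that (a hydrogen atom in place of a group of 4 heavy atoms (3 oxygen, 1 phosphorus; no ring), on an oxygen). Going by the values given here, the one measured step of the same kind, a step that the two limits leave unreadable from compound 1 to compound 2, is unreadable from its two limits. With the limit of > 1000 nM in this assay, at which 3 of the 3 values shown sit, no direction or size beyond the scatter can be expected in this assay, and compound 4 is estimated to stay at the limit, a step that the limit leaves unreadable from compound 2 to compound 4. Compound 4 is expected to give 10000 nM, between 1000 nM and 100000 nM.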

Compound 4, half-maximal effective concentration: >= 100000 nM
Compound 4: a limit, no number; the forecaster's own chance of this, stated with the estimate: 90%; middle value at least 10-fold (1.00 log units) away from the limit.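

Compound 1, compound 2 and compound 4 all stand at limits, and the steps among them cannot be read. The compounds shown leave open whether removing phosphate groups changes the effect in this assay at all, and in which direction.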